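The source may report more compounds than this note shows. Statements on the series, on what has been measured and on what is new or still open speak of the compounds shown alone.

Measured compounds:
Compound 1, `O=C(/C=C/c1ccccc1)Nc1cc2c(Nc3ccc(Cl)c(Cl)c3)ncnc2s1`: in a functional assay on PC-3 cells (Homo sapiens) for antiproliferative activity, read by MTT assay, with a stated time of 48 h (a higher number here means a weaker inhibitor, a lower number a stronger inhibitor), compound 1 gives 480 nM.
Compound 2, `O=C(/C=C/c1ccccc1)Nc1cc2ncnc(Nc3cc(Cl)cc(Cl)c3)c2s1`: in this assay compound 2 gives 220 nM.
Compound 3, `O=C(/C=C/c1ccccc1)Nc1cc2c(Nc3cc(Cl)cc(Cl)c3)ncnc2s1`: in this assay compound 3 gives 390 nM.

Compound 1 and compound 3 share one core; compound 2 carries a second core, and the difference between the two cores is not broken down here. Compound 3 and compound 1 differ by 3,4-dichlorophenyl in place of 3,5-dichlorophenyl on a nitrogen on an aromatic ring, a step of a 1.2-fold higher number from compound 3 to compound 1 (0.09 log units; within the scatter). Compound 2 stands lowest of the three numbers, within the scatter of compound 3 and beyond it only against compound 1.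

Compound 4, `O=C(/C=C/c1ccccc1)Nc1cc2ncnc(Nc3ccc(Cl)c(Cl)c3)c2s1`, has not been measured in this assay. It differs from compound 2 by 3,4-dichlorophenyl in place of 3,5-dichlorophenyl on a nitrogen on an aromatic ring, the same change in the same place as from compound 3 to compound 1, now on the core of compound 2.

Going by the values given here, the step from compound 2 to compound 4 is expected to be a 1.2-fold higher number from compound 2 to compound 4 (0.09 log units; within the scatter), resting on the single earlier measured instance a 1.2-fold higher number from compound 3 to compound 1 (0.09 log units; within the scatter). Compound 4 is therefore estimated at 270 nM, between 130 nM and 560 nM.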

Compound 4, half-maximal inhibitory concentration: 260 nM
The estimate for compound 4 lay 1.0-fold (0.02 log units) above the measured number; measured number inside the range.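

In this assay, placing 3,4-dichlorophenyl in place of 3,5-dichlorophenyl on the nitrogen on the aromatic ring gives a 1.2-fold higher number from compound 2 to compound 4 (0.07 log units; within the scatter). The two cores show no readable difference in the size of this step: the same change on two cores in this assay, a 1.2-fold higher number (0.09 log units; within the scatter) from compound 3 to compound 1 and a 1.2-fold higher number (0.07 log units; within the scatter) from compound 2 to compound 4, 1.0-fold (0.02 log units) apart, within the scatter of two such steps. Going by these compounds alone, this shows only that the change leaves the number within the scatter on these two cores; with two pairs and both steps inside the scatter, it does not show that the same would hold on any other core or for any other change.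

Still open, on these data alone, is whether other groups on that nitrogen, such as unsubstituted phenyl or methoxyphenyl, would behave alike on both cores. Also open, as far as these compounds go, is the effect of an amine or a carboxylic acid on the phenyl of the amide chain.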